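A few compounds are considered here, and "the series" means these few. Any claim that something is new, unique, unknown or untested is made for them only; others in the source may bear on it.

Three compounds have been measured in a functional assay on PC-9 cells (Homo sapiens) for inhibition, read by MTT assay, with a stated time of 72 h; a lower number here means a stronger inhibitor, a higher number a weaker inhibitor:
Compound 1, `Cc1cc(Nc2cc(-c3ccccc3)[nH]n2)n2nc(SCc3c(Cl)cccc3Cl)nc2n1`, gives 5180 nM.
Compound 2, `Cc1cc(Nc2cc(-c3ccccc3)[nH]n2)n2nc(SCc3ccc([N+](=O)[O-])cc3)nc2n1`, gives 7980 nM.
Compound 3, `Cc1cc(Nc2cc(-c3ccccc3)[nH]n2)n2nc(SCc3ccc(Cl)cc3)nc2n1`, gives 6710 nM.

Compound 2 shows the highest of the three numbers, yet its distance to each of the others stays within the scatter: a 1.2-fold lower number from compound 2 to compound 3 (0.08 log units; within the scatter), and a 1.5-fold higher number from compound 1 to compound 2 (0.19 log units; within the scatter). Compound 4, `CCCSc1nc2nc(C)cc(Nc3cc(-c4ccccc4)[nH]n3)n2n1`, has not yet been measured. It differs from compound 2 in one place: ethyl in place of 4-nitrophenyl on a saturated chain carbon bound to a sulfur. The measured steps that touch this part of the molecule, a 1.5-fold higher number from compound 1 to compound 2 (0.19 log units; within the scatter) and a 1.3-fold higher number from compound 1 to compound 3 (0.11 log units; within the scatter), each exchange one aromatic group for another on a saturated chain carbon bound to a sulfur, and both stay within the scatter. Among the measured compounds shown here, neither removes the aromatic ring altogether, as the change to compound 4 does, so there is no direct precedent for it. Since all three numbers seen so far sit close together, no step beyond the scatter is expected here either, though the missing precedent widens the range. Compound 4 is therefore estimated at about 9000 nM, expected to fall between 3000 nM and 30000 nM, which corresponds to an expected step of a 1.1-fold higher number from compound 2 to compound 4 (0.05 log units; within the scatter).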

Compound 4, half-maximal inhibitory concentration: > 50000 nM
Compound 4 was reported as a limit; the forecaster's own chance of this, stated with the estimate: 10%; at least 5.5-fold (0.74 log units) between middle value and limit.
By their numbers in this assay, from the lowest: compounds 1, 3 and 2 (each within the scatter of the next). At a limit, above all of these: compound 4.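

In this assay compound 4 is reported as a limit and not as a number: the limit of > 50000 nM in this assay, at which 1 of the 4 values shown sits.

Among the compounds shown here, exchanging one aromatic group for another on a saturated chain carbon bound to a sulfur had stayed within the scatter, which made this position look forgiving, but replacing the aromatic ring with ethyl is the first change here to go beyond it, with an at least 6.2-fold higher number from compound 2 to compound 4 (0.79 log units; beyond the scatter), an at least 7.4-fold higher number from compound 3 to compound 4 (0.87 log units; beyond the scatter) and an at least 9.6-fold higher number from compound 1 to compound 4 (0.98 log units; beyond the scatter). Among these four compounds, then, the three that keep an aromatic ring at this position all give measurable numbers whatever the ring carries, and the one without a ring is the one that sits at the limit, with no compound shown going against this.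

The change removes the ring and also shrinks the group, from 9 heavy atoms to 2, so these compounds cannot say which of the two matters; a cyclohexyl group or a longer chain such as hexyl in this place would separate them. As far as these compounds go, how an amine or a carboxylic acid in this place would read also stays open.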